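Swapping a difluorophenyl for a bromophenyl on the shared core

The compounds below may be only part of what the source reports. "The series", "measured", "known", "first", "only" and "open" are said of these compounds alone.

Measured so far in a functional assay on U-251 cells (Homo sapiens) for cytotoxicity (on this read-out higher numbers stand for weaker inhibition of growth and lower numbers for stronger inhibition of growth), for three compounds
- compound 1 `COc1ccc(C2=C(c3ccc(SC)cc3)CC3CCCN3C2=O)cc1OC(=O)CNC(=O)OC(C)(C)C` gives 6000 nM 
- compound 2 `COc1ccc(C2=C(c3ccc(SC)cc3)CC3CCCN3C2=O)cc1C` gives 90 nM 
- compound 3 `CSc1ccc(C2=C(c3ccc(F)c(F)c3)C(=O)N3CCCC3C2)cc1` gives 15000 nM 

Compound 3 has the highest number of the three, so it inhibits growth least. The next compound, compound 4 `CSc1ccc(C2=C(c3ccc(Br)cc3)C(=O)N3CCCC3C2)cc1`, differs from it by one change (4-bromophenyl in place of 3,4-difluorophenyl on a double-bonded ring carbon), with 4-bromophenyl in place of 3,4-difluorophenyl on a double-bonded ring carbon. Going by the values given here, the closest precedent at that carbon is a 170-fold higher number from compound 2 to compound 3 (2.22 log units; beyond the scatter), a large step. On the same aryl group, a 67-fold lower number from compound 1 to compound 2 (1.82 log units; beyond the scatter) was also large. Among the compounds with values here, both steps removed or brought in groups far unlike a halogen swap, and no measured compound carries 4-bromophenyl. In this assay, from the compounds shown here alone, no step beyond the scatter is therefore expected, and the direction stays open. The estimated step is a 1.9-fold lower number from compound 3 to compound 4 (0.27 log units; within the scatter) as a best guess. For compound 4 the expected value is 8000 nM within a range of 2000 nM to 30000 nM as an estimate.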

Compound 4, concentration for 50% growth inhibition: 7000 nM
Compound 4: the middle estimate sits 1.1-fold (0.06 log units) above what was measured; low and high end bracket the measured number.
By their numbers in this assay, from the lowest: compound 2; then compounds 1 and 4 (each within the scatter of the next); then compound 3.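

Changing one halogen-bearing phenyl for another on the double-bonded ring carbon has only a modest effect in this assay (a 2.1-fold lower number from compound 3 to compound 4 (0.33 log units; beyond the scatter)). A much larger gap separates the halogen-bearing compound 4 from the methoxy- and methyl-bearing group (a 78-fold higher number from compound 2 to compound 4 (1.89 log units; beyond the scatter)), so 4-methoxy-3-methylphenyl remains far stronger than 4-bromophenyl here. No available evidence explains either step.

From the compounds shown here alone, it remains open whether a phenyl ring carrying an amine or a carboxylic acid at this carbon would approach compound 2. The compounds also cannot separate the effect of adding bromine from that of removing both fluorines.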